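The compounds below may be only part of what the source reports. "The series", "measured", "known", "first", "only" and "open" are said of these compounds alone.

Three compounds from this study, compound 1 `C=C1[C@H](OC(C)=O)[C@H]2[C@@H](OC(=O)c3ccccc3)[C@@H](C)C[C@]2(OC(C)=O)C(=O)[C@@H](C)/C=C/C(C)(C)C(=O)[C@H](OC(C)=O)[C@H]1OC(C)=O`, compound 2 `C=C1[C@H](OC(C)=O)[C@H]2[C@@H](OC(=O)c3ccccc3)[C@@H](C)C[C@]2(OC(C)=O)C(=O)[C@@H](C)/C=C/C(C)(C)C(=O)[C@H](O)[C@H]1OC(C)=O` and compound 3 `C=C1[C@H](OC(C)=O)[C@H]2[C@@H](OC(=O)c3ccccc3)[C@](C)(O)C[C@]2(O)C(=O)[C@@H](C)/C=C/C(C)(C)C(=O)[C@H](OC(=O)C(C)C)[C@H]1OC(C)=O`, were tested in an ADME assay on NCI/ADR-RES cells (Homo sapiens) for cytotoxicity, read by MTT assay, with a stated time of 48 h; a higher number here means a weaker inhibitor, a lower number a stronger inhibitor. In this assay compound 1 gives only a limit, > 100000 nM. Compound 2 likewise gives only a limit in this assay, > 100000 nM. Compound 3 too gives only a limit in this assay, > 100000 nM. Every value recorded so far sits at the same point, namely (the limit of > 100000 nM in this assay, at which 3 of the 3 values shown sit).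

Compound 1 differs from compound 2 in one place: acetyl in place of hydrogen on an oxygen on a saturated carbon. The step that the two limits leave unreadable from compound 2 to compound 1 cannot be read, since both values are limits. Compound 3 shares much with compound 2, but the difference between the two cores is not broken down here.

A fourth compound, compound 4 `C=C1[C@H](OC(C)=O)[C@H]2[C@@H](OC(=O)c3ccccc3)[C@](C)(OC(C)=O)C[C@]2(O)C(=O)[C@@H](C)/C=C/C(C)(C)C(=O)[C@H](OC(=O)C(C)C)[C@H]1OC(C)=O`, remains to be measured in this assay. It differs from compound 3 by acetyl in place of hydrogen on an oxygen on a saturated carbon, which is the same change as that from compound 2 to compound 1, made at the same kind of position. Because the limit of > 100000 nM in this assay, at which 3 of the 3 values shown sit, holds every value seen so far, the earlier step gives no direction to borrow, and the change is expected to leave compound 4 at or near the same limit. The step that the limit leaves unreadable from compound 3 to compound 4 is therefore expected to be small or unreadable. Compound 4 is expected to give about 150000 nM in this assay, with a range from 50000 nM to 500000 nM.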

Compound 4, half-maximal inhibitory concentration: > 100000 nM
Compound 4: only a limit was reported (the forecaster's own chance of this, stated with the estimate: 85%); the middle value lies beyond the limit too.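

In this assay compound 4 gives only a limit, > 100000 nM. Compound 3 also stands at a limit, so the change from hydroxy to acetoxy between compound 3 and compound 4 cannot be read, and all values sit at one point: the limit of > 100000 nM in this assay, at which 4 of the 4 values shown sit.

The compounds shown leave open how strong any of the four actually is in this assay, and so whether this change has any effect there.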